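Swapping the carboxy ring group for a hydroxy

This account rests on a few compounds, and the source may have more. Where it says the series, first, only, none or still open, it means among the compounds named here.

Measured in a functional assay on HeLa cells (Homo sapiens) for antiproliferative activity, read by CCK-8 assay, with a stated time of 48 h (a higher number here means a weaker inhibitor, a lower number a stronger inhibitor), as follows
- compound 1 `COc1ccc(/C=C\c2cc(OC)c(OC)c(OC)c2)cc1OCc1ccc(CN2C[C@H](O)C[C@@H]2C(=O)O)cc1` gives > 10000 nM as a limit
- compound 2 `COc1ccc(/C=C\c2cc(OC)c(OC)c(OC)c2)cc1OCc1ccc(CN2CCCCC2C(=O)O)cc1` gives 14200 nM as a number
- compound 3 `COc1ccc(/C=C\c2cc(OC)c(OC)c(OC)c2)cc1OCc1ccc(CN2CC[C@H](C(=O)O)C2)cc1` gives > 10000 nM as a limit

Compound 3 has no number of its own and stands only at the limit of > 10000 nM in this assay, at which 2 of the 3 values shown sit, in a group with compound 1. Among the measured compounds shown here, compound 2 is the only one of the three with a true number, and that number is 14200 nM in this assay for this series so far.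

The next change leads to compound 4 `COc1ccc(/C=C\c2cc(OC)c(OC)c(OC)c2)cc1OCc1ccc(CO)cc1` and reads hydroxy in place of 3-carboxypyrrolidin-1-yl on a saturated chain carbon bound to an aromatic carbon on the shared core. In short, (3-carboxypyrrolidin-1-yl)methyl becomes hydroxymethyl.

The nearest measured steps are a step that the limit leaves unreadable from compound 1 to compound 2 along with a step that the two limits leave unreadable from compound 1 to compound 3 and a step that the limit leaves unreadable from compound 2 to compound 3 and each of them trades one carboxy ring group for another. None of them has a readable size, and none removes such a group, so they offer only indirect guidance. All three measured compounds carry such a group, and compound 2 at 14200 nM shows weak inhibition even with a number to read. Removing the group altogether is therefore expected to give a stronger inhibitor, though this is uncertain.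

The estimated step is an at least 3.3-fold lower number from compound 3 to compound 4 (0.52 log units; beyond the scatter) in that direction.

For compound 4 the estimate is 3000 nM with an expected range from 200 nM to 20000 nM in this assay as the working expectation.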

Compound 4, half-maximal inhibitory concentration: 7600 nM
Beside the measured number, compound 4's estimate is 2.5-fold (0.40 log units) below it; the measured number falls inside the stated range.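

In this assay compound 4 is the first compound shown with no carboxy ring group on the saturated chain carbon bound to an aromatic carbon, and it still gives a true number, so a lone hydroxy can stand at this place without pushing the reading to a limit. Among the compounds shown here, the one comparison between two true numbers is a 1.9-fold lower number from compound 2 to compound 4 (0.27 log units; within the scatter) and so does not separate the two compounds, which means that trading 2-carboxypiperidin-1-yl for hydroxy has no readable effect here. Compounds 1 and 3 stand only at limits, so an at least 1.3-fold lower number from compound 3 to compound 4 (0.11 log units; that floor lies within the scatter) and an at least 1.3-fold lower number from compound 1 to compound 4 (0.11 log units; that floor lies within the scatter) give floors and not sizes, and a larger step is neither shown nor ruled out: the limit of > 10000 nM in this assay, at which 2 of the 4 values shown sit.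

The compounds shown leave open whether a plain amine, such as a pyrrolidin-1-yl group without its carboxylic acid, or a longer chain ending in hydroxy would read any differently from hydroxy at this place. On these data alone, the true positions of compound 1 and compound 3 also stay open, and with them the real size of any step that starts from either compound.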